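Secondary amide in place of tertiary amide

This account rests on a few compounds, and the source may have more. Where it says the series, first, only, none or still open, it means among the compounds named here.

Compound 1, `COc1cc2c(cc1OC)C(CC(=O)O)CC2`, gives 44% in a functional assay on the whole organism (strain Swiss albino) for inhibition, with Mus musculus as the target, in the writhing test, with stated times of 60 min and 15 min, at a dose of 100 mg/kg by the oral route; a higher number here means more inhibition at the dose given (going by the name of the read-out), a lower number less inhibition. Compound 2, `COc1cc2c(cc1OC)C(CC(=O)N(C)C)CC2`, gives 22.6% in this assay. For the measured compounds named here, the one measured step in the set, a number 21.4 percentage points lower from compound 1 to compound 2 (beyond the scatter), was beyond the scatter and in the downward direction. Going by the values given here, compound 2 therefore stands lowest of the two numbers so far in this assay, with compound 1 the nearest neighbour and above it.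

Compound 3, `CCCNC(=O)CC1CCc2cc(OC)c(OC)cc21`, is not yet measured. It differs from compound 2 as follows: propylamino in place of dimethylamino on a carbonyl carbon. Among the compounds with values here, the only step in hand, from an acid to a dimethylamide, does not match this change, since compound 3 keeps an amide and gains one hydrogen-bond donor while the measured step removed an acid. Within the data shown here, no measured step bears directly on it, so the expectation rests on the neighbours alone. The step is expected to be a number 7.4 percentage points higher from compound 2 to compound 3 (within the scatter), small and within the scatter or slightly upward. Compound 3 is estimated at 30% in this assay, within a range of 12% to 48%.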

Compound 3, a percentage reported as inhibition, in the whole organism at one dose (the size of the read-out at that dose, not a potency): 26.9%
Estimate against measurement, compound 3: 3.1 percentage points above; the range from low to high includes it.
By their numbers in this assay, from the lowest: compounds 2 and 3 (each within the scatter of the next); then compound 1.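

In this assay the change from dimethylamino to propylamino on a carbonyl carbon gives a number 4.3 percentage points higher from compound 2 to compound 3 (within the scatter) and so does not separate these two amides at this dose, although propylamino carries a hydrogen-bond donor and dimethylamino does not. Against the acid, the propylamino amide gives a number 17.1 percentage points lower from compound 1 to compound 3 (beyond the scatter) in this assay and so shows the same direction as the dimethylamino amide, which means that the drop from hydroxy at this carbonyl carbon now holds for two different amides, with no amide in the set going against it. Nothing available explains the drop or the absence of a separation between the two amides.

The compounds shown leave open whether an unsubstituted amino group on the carbonyl carbon, or a methoxy group giving the methyl ester, would stay with the amides or come closer to the acid. They also leave open whether a longer chain such as octylamino, or a ring amine such as morpholine, would separate from propylamino in this read-out, which reports a single dose and gives no potency.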